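The source may report more compounds than this note shows. Statements on the series, on what has been measured and on what is new or still open speak of the compounds shown alone.

Measured so far in a functional assay on MCF7 cells (Homo sapiens) for antiproliferative activity, read by MTT assay; on this read-out higher numbers stand for weaker inhibition and lower numbers for stronger inhibition:
- compound 2 `CCOC(=O)/C=N/c1cnc(Nc2ccc(N3CCN(C)CC3)cc2)nc1NC(C)C` gives 12300 nM
- compound 3 `CCOC(=O)/C=N/c1cnc(Nc2ccc(S(N)(=O)=O)cc2)nc1NC(C)C` gives 58800 nM
- compound 1 `NS(=O)(=O)c1ccc(Nc2ncc(/N=C/c3ccc(C(F)(F)F)cc3)c(NC3CCCC3)n2)cc1` sits at a limit of this assay, > 100000 nM

Compound 3 stands at the highest of the two numbers in this assay; its nearest neighbour is compound 2, and the step is a 4.8-fold higher number from compound 2 to compound 3 (0.68 log units; beyond the scatter). Going by the values given here, the only measured step, sulfamoyl in place of 4-methylpiperazin-1-yl, concerns a different part of the molecule and bears on the present change only as a sign that the shared core already sits at weak inhibition.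

Compound 4 `CC(C)Nc1nc(Nc2ccc(S(N)(=O)=O)cc2)ncc1/N=C/c1ccc(C(F)(F)F)cc1` differs from compound 3 by 4-(trifluoromethyl)phenyl in place of ethoxycarbonyl on a carbon with a double bond to nitrogen. Among the compounds with values here, no measured pair differs exactly in this way. Compound 1 carries the same 4-(trifluoromethyl)phenyl imine and the same sulfamoyl group and is one of the values at the limit of > 100000 nM in this assay, at which 1 of the 3 values shown sits. On that basis, compound 4 is expected to move further up, with the step of a 2.6-fold higher number from compound 3 to compound 4 (0.41 log units; beyond the scatter), and a fair chance that this assay reports only a limit. The estimate for compound 4 is 150000 nM, ranging from 40000 nM to 500000 nM.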

Compound 4, half-maximal inhibitory concentration: > 100000 nM
Compound 4 ended at the assay's limit; the forecaster's own chance of this, stated with the estimate: 60%; the middle value lies beyond the limit too.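

In this assay, as far as these compounds go, 4-(trifluoromethyl)phenyl in place of ethoxycarbonyl on a carbon with a double bond to nitrogen gives an at least 1.7-fold higher number from compound 3 to compound 4 (0.23 log units; that floor lies within the scatter), so this change brings no gain in inhibition and its true size stays unknown. The 4-(trifluoromethyl)phenyl imine with the sulfamoyl group gives no readable number with either isopropyl or cyclopentyl on the nitrogen on an aromatic ring. Compound 1 and compound 4 both stop at a limit, and the step between them cannot be read: the limit of > 100000 nM in this assay, at which 2 of the 4 values shown sit.

The compounds shown leave open whether the 4-(trifluoromethyl)phenyl imine would give a readable number with 4-methylpiperazin-1-yl in place of sulfamoyl. They also leave open how a carboxylic acid or a primary amide on this carbon would read in this assay.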